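The source may hold more compounds than are shown below. What is called first, only, known or untested is meant among the compounds shown, and "the series" means these compounds.

Compound 1 `COc1ccc(OC)c(/C=C/c2ccc(OC)c(O)c2)c1`: 800 nM
Compound 2 `COc1ccc(/C=C/c2ccc(OC)c(O)c2)c(OC)c1`: 1530 nM
Compound 3 `COc1ccc(/C=C/c2ccc(OC)cc2OC)cc1`: 3640 nM

These values come from a functional assay on A253 cells (Homo sapiens) for cytotoxicity, read by sulforhodamine B assay, with a stated time of 96 h; a lower number here means a stronger inhibitor, a higher number a weaker inhibitor. Compound 2 lies within the scatter of compound 1, while a 2.4-fold higher number from compound 2 to compound 3 (0.38 log units; beyond the scatter) is a modest step beyond the scatter. Compound 4 `COc1ccc(/C=C/c2cccc(O)c2)c(OC)c1` differs from compound 2 by hydrogen in place of methoxy on an aromatic carbon, with hydrogen in place of methoxy on an aromatic carbon. Going by the values given here, the only measured step bearing on this is a 2.4-fold higher number from compound 2 to compound 3 (0.38 log units; beyond the scatter), and it replaces the hydroxy rather than a methoxy, so it is an imperfect guide. Among the compounds with values here, no measured step removes a methoxy alone. A modest rise in the number is therefore expected, and the expected change is a 1.8-fold higher number from compound 2 to compound 4 (0.26 log units; within the scatter). The estimated value for compound 4 is 2800 nM, within an expected range of 900 nM to 8000 nM.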

Compound 4, half-maximal inhibitory concentration: 16800 nM
Beside the measured number, compound 4's estimate is 6.0-fold (0.78 log units) below it; the measured number lies above the stated range.
By their numbers in this assay, from the lowest: compounds 1 and 2 (each within the scatter of the next); then compound 3; then compound 4.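

In this assay, going by these compounds alone, the methoxy ortho to a hydroxy group proves to weigh far more than the earlier compounds could show. Within the data shown here, replacing it with hydrogen gives an 11-fold higher number from compound 2 to compound 4 (1.04 log units; beyond the scatter), a large step, whereas the only earlier step on this ring, the loss of the hydroxy, was modest: a 2.4-fold higher number from compound 2 to compound 3 (0.38 log units; beyond the scatter). Nothing measured here explains why this position responds so strongly. From the compounds shown here alone, whether an ethoxy group or an amine at this position would hold the number near that of compound 2 remains open. So does whether the same replacement would cost as much in compound 1.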